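A few compounds are considered here, and "the series" means these few. Any claim that something is new, unique, unknown or untested is made for them only; others in the source may bear on it.

Measured so far in a functional assay on M21 cells (Homo sapiens) for antiproliferative activity, read by sulforhodamine B assay, with a stated time of 48 h; a lower number here means a stronger inhibitor, a higher number a weaker inhibitor:
- compound 1 `CCc1ccccc1OS(=O)(=O)c1ccc(N2CCN(C)C2=O)cc1`: 2300 nM
- compound 2 `CN1CCN(c2ccc(S(=O)(=O)Oc3ccc(F)cc3)cc2)C1=O`: > 100000 nM (a limit)
- compound 3 `CCCN1CCN(c2ccc(S(=O)(=O)Oc3ccccc3CC)cc2)C1=O`: > 50000 nM (a limit)

Compound 3 therefore has no exact number, only a limit, and so does one other compound in the series. Only compound 1 has a measured number.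

Next in the series is compound 4 `CCCN1CCN(c2ccc(S(=O)(=O)Oc3c(Cl)cc(Cl)cc3Cl)cc2)C1=O`. It keeps the chain of compound 3 and carries 2,4,6-trichlorophenyl in place of 2-ethylphenyl on an oxygen. Among the measured compounds shown here, no measured compound carries this group.

For the measured compounds named here, two measured steps bear on the change, both large and beyond the scatter. Going by the values given here, the only measured exchange on that oxygen, 4-fluorophenyl in place of 2-ethylphenyl, gave an at least 43-fold higher number from compound 1 to compound 2 (1.63 log units; beyond the scatter). The chain change, which compound 4 retains, gave an at least 21-fold higher number from compound 1 to compound 3 (1.33 log units; beyond the scatter). On these data alone, both steps end at limits, so their true sizes remain open.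

Among the compounds with values here, with an at least 21-fold higher number from compound 1 to compound 3 (1.33 log units; beyond the scatter) as the only measured chain step, and with the oxygen exchange in an at least 43-fold higher number from compound 1 to compound 2 (1.63 log units; beyond the scatter) offering no sign of a gain, no step beyond the scatter is expected in this assay. The expected change is an at least 1.2-fold lower number from compound 3 to compound 4 (0.09 log units; that floor lies within the scatter). For compound 4 the estimated value is 40000 nM, with an expected range of 10000 nM to 100000 nM.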

Compound 4, half-maximal inhibitory concentration: 56000 nM
Compound 4: middle estimate off by 1.4-fold (0.15 log units), on the low side; measured number inside the range.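

No step can be read from compound 3 to compound 4 in this assay, because compound 3 stands only at a limit: the limit of > 50000 nM in this assay, at which 1 of the 4 values shown sits.

The compounds shown leave open how large the exchange of 2-ethylphenyl for 2,4,6-trichlorophenyl on an oxygen is in this assay, and whether it would act alike on compound 1.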